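The source may report more compounds than this note shows. Statements on the series, on what has been measured and on what is new or still open speak of the compounds shown alone.

The measured compounds and their values:

Compound 1, `CCO[C@@H]1O[C@H](CNC(=O)c2ccc(S(N)(=O)=O)cc2)[C@@H](O)[C@H](O)[C@H]1N`, gives 58.6 h in an ADME assay on microsomes from liver (Mus musculus) for metabolic stability; on this read-out higher numbers stand for a longer-lived compound and lower numbers for a shorter-lived compound.
Compound 2, `CCO[C@@H]1O[C@H](CNC(=O)c2ccc(S(N)(=O)=O)cc2)[C@H](O)[C@H](O)[C@H]1O`, gives 61.1 h in this assay.
Compound 3, `CCCO[C@@H]1O[C@H](CNC(=O)c2ccc(S(N)(=O)=O)cc2)[C@H](O)[C@H](O)[C@H]1O`, gives 66.4 h in this assay.

The three numbers lie within the usual scatter of one another, so they cannot be put in any order. Compound 2 and compound 3 differ in a single place: methyl in place of hydrogen on a saturated chain carbon, two bonds along the chain from an oxygen on a saturated carbon. That change is the only one for which a measured step exists, and it gave a 1.1-fold higher number from compound 2 to compound 3 (0.04 log units; within the scatter). Compound 1 and compound 2 differ in a larger way; the difference between the two cores is not broken down here.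

Compound 4, `CCCO[C@@H]1O[C@H](CNC(=O)c2ccc(S(N)(=O)=O)cc2)[C@@H](O)[C@H](O)[C@H]1N`, has not yet been measured in this assay. It differs from compound 1 by methyl in place of hydrogen on a saturated chain carbon, two bonds along the chain from an oxygen on a saturated carbon. For the measured compounds named here, this is the same change as the one from compound 2 to compound 3, made at the same place, so the only guide to its effect is that earlier step. Because that step gave a 1.1-fold higher number from compound 2 to compound 3 (0.04 log units; within the scatter), and because compound 1 gives 58.6 h, the expectation is that the number for compound 4 will sit close to the number for compound 1. The expected step from compound 1 to compound 4 is a 1.1-fold higher number from compound 1 to compound 4 (0.03 log units; within the scatter). Compound 4 is therefore estimated to give about 63 h in this assay, with a likely range from 40 h to 100 h.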

Compound 4, half-life: 64.4 h
Compound 4: middle estimate off by 1.0-fold (0.01 log units), on the low side; the range from low to high includes it.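

Adding one methyl to turn ethoxy into propoxy on the core of compound 1 gave a 1.1-fold higher number from compound 1 to compound 4 (0.04 log units; within the scatter) in this assay. Set beside the same change on the core of compound 2, the step looks the same on both cores: the same change on two cores in this assay, a 1.1-fold higher number (0.04 log units; within the scatter) from compound 2 to compound 3 and a 1.1-fold higher number (0.04 log units; within the scatter) from compound 1 to compound 4, 1.0-fold (0.00 log units) apart, within the scatter of two such steps. This shows that, on these two cores, lengthening the chain by one carbon moved the number by no more than repeated measurements of one compound would, so the agreement is an agreement between two small steps, not a repeated gain; it does not show that the change has any real effect on the half-life, and two cores are too few to say how it would behave on a core not shown here.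

From the compounds shown here alone, what remains open is whether a longer chain such as butoxy, a branched chain such as isopropoxy, or a ring in place of the chain would move the number beyond the scatter on either core. Also open, going by these compounds, is whether an amine or a carboxylic acid at the end of that chain would leave the number where these four compounds sit, or shift it clearly in one direction.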